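This account rests on a few compounds, and the source may have more. Where it says the series, first, only, none or still open, it means among the compounds named here.

Compound 1 `COc1ccc(Nc2cc(-c3ccccc3)oc(=O)c2)cc1` gives 0.098 uM in a functional assay on KBVIN cells (Homo sapiens) for cytotoxicity, read by MTT assay, with a stated time of 72 h (a lower number here means that less compound is needed, a higher number that more compound is needed for the effect), the lowest of the two numbers shown. Compound 3 `COc1ccc(Nc2cc(/C=C/c3ccccc3)oc(=O)c2)cc1` gives 0.1 uM; the step of a 1.0-fold higher number from compound 1 to compound 3 (0.01 log units; within the scatter) is within the scatter. Compound 2 `COc1ccc(Nc2cc(C)oc(=O)c2)cc1` reaches only a limit, > 30 uM, so the limit of > 30 uM in this assay, at which 1 of the 3 values shown sits, is all that is known of it, and an at least 300-fold higher number from compound 1 to compound 2 (2.48 log units; beyond the scatter) is accordingly large. Compound 4 `Cc1ccc(Nc2cc(-c3ccccc3)oc(=O)c2)cc1` differs from compound 1 in another place: methyl in place of methoxy on an aromatic carbon. Among the measured compounds shown here, no measured step touches this part of the shared core; the two measured steps concern the phenyl on the other ring. The step is therefore expected to stay within the scatter, a 1.5-fold higher number from compound 1 to compound 4 (0.18 log units; within the scatter). Compound 4 is estimated at 0.15 uM, between 0.04 uM and 0.6 uM.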

Compound 4, concentration for half-maximal effect: 0.059 uM
Compound 4: middle estimate off by 2.5-fold (0.41 log units), on the high side; low and high end bracket the measured number.
By their numbers in this assay, from the lowest: compounds 4, 1 and 3 (each within the scatter of the next). At a limit, above all of these: compound 2.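

At this position, on a six-membered aromatic ring of carbon only and para to a large group, methyl in place of methoxy gives a 1.7-fold lower number from compound 1 to compound 4 (0.22 log units; within the scatter). The earlier steps shown here concerned only the group on the other ring, whereas this one shows that the number in this assay holds without the oxygen of the methoxy, the hydrogen-bond acceptor that leaves. Nothing measured here gives a cause for this step. From the compounds shown here alone, whether an amine, a carboxylic acid or a longer chain at this position would keep the number remains open, as does the effect of leaving this position empty.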